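Thiophen-3-yl in place of methyl on the core

The source may hold more compounds than are shown below. What is called first, only, known or untested is meant among the compounds shown, and "the series" means these compounds.

In a functional assay on CCRF-CEM cells (Homo sapiens) (on this read-out higher numbers stand for lower toxicity in this test and lower numbers for higher toxicity in this test), compound 1 `CNC1=C(C)S(=O)(=O)O[C@@]12[C@@H](CO[Si](C)(C)C(C)(C)C)O[C@@H](n1cc(C)c(=O)n(C)c1=O)[C@@H]2O[Si](C)(C)C(C)(C)C` gives 234000 nM and compound 2 `CC1=C(N)[C@@]2(OS1(=O)=O)[C@@H](CO[Si](C)(C)C(C)(C)C)O[C@@H](n1cc(C)c(=O)n(C)c1=O)[C@@H]2O[Si](C)(C)C(C)(C)C` gives 10000 nM, the lower of the two numbers. Compound 3 `Cc1cn([C@@H]2O[C@H](CO[Si](C)(C)C(C)(C)C)[C@@]3(OS(=O)(=O)C(c4ccsc4)=C3N)[C@H]2O[Si](C)(C)C(C)(C)C)c(=O)n(C)c1=O` is the next point: thiophen-3-yl in place of methyl on a double-bonded ring carbon. Within the data shown here, the only measured step, a 23-fold lower number from compound 1 to compound 2 (1.37 log units; beyond the scatter), is large but sits on the amine nitrogen, so it gives no direction for this change. The data show nothing at this ring carbon, so no clear move beyond the scatter is expected. The estimated step is a 1.2-fold higher number from compound 2 to compound 3 (0.08 log units; within the scatter). For compound 3 the expected value is 12000 nM, with an estimated range of 3000 nM to 60000 nM.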

Compound 3, half-maximal cytotoxic concentration: 33000 nM
Compound 3: the middle estimate sits 2.8-fold (0.44 log units) below what was measured; the range from low to high includes it.
By their numbers in this assay, from the lowest: compound 2; then compound 3; then compound 1.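

In this assay the double-bonded ring carbon gives its first reading, a 3.3-fold higher number from compound 2 to compound 3 (0.52 log units; beyond the scatter), so this position is not silent. Thiophen-3-yl in place of methyl shifts the number modestly toward lower toxicity in this test, a shift that the amine step gave no sign of. Nothing available explains this shift.

On these data alone, whether phenyl, thiophen-2-yl or a plain hydrogen on this carbon would shift the number the same way remains open. Also open, as far as these compounds go, is whether the thiophen-3-yl step holds when the amine carries a methyl.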